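Swapping an aromatic ring for tert-butyl on a shared core

The source may report more compounds than this note shows. Statements on the series, on what has been measured and on what is new or still open speak of the compounds shown alone.

Compound 1 `Cc1cc(Nc2cc(-c3ccc(Cl)cc3)[nH]n2)n2nc(SCc3ccc(Br)cc3)nc2n1` was tested in a functional assay on PC-9 cells (Homo sapiens) for inhibition, read by MTT assay, with a stated time of 72 h (a lower number here means a stronger inhibitor, a higher number a weaker inhibitor), where compound 1 gives 4920 nM. Of the two numbers available it is the higher, yet its closest neighbour, compound 2 `Cc1cc(Nc2cc(-c3ccccc3)[nH]n2)n2nc(SCc3nc4ccccc4[nH]3)nc2n1`, gives 4840 nM, and the two values sit within the usual scatter, so neither can be called stronger. A third compound, compound 3 `Cc1cc(Nc2cc(-c3ccccc3)[nH]n2)n2nc(SCC3CC3)nc2n1`, reaches only a limit of the assay, > 50000 nM, as noted in the limit of > 50000 nM in this assay, at which 1 of the 3 values shown sits. Within the data shown here, the one measured step, an at least 10-fold higher number from compound 2 to compound 3 (1.01 log units; beyond the scatter), replaces a ring-bearing group on the sulfur chain with a ring-free one and costs a great deal of potency.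

Compound 4 `Cc1cc(Nc2cc(C(C)(C)C)[nH]n2)n2nc(SCc3ccc(Br)cc3)nc2n1` differs from compound 1 at another place: tert-butyl in place of 4-chlorophenyl on an aromatic carbon. A six-membered aromatic ring of carbon only leaves, and a group with no ring enters. Among the measured compounds shown here, no measured step touches this position, so the step from compound 2 to compound 3 offers only a loose parallel, hinting that loss of a ring can weaken the compounds. Compound 4 is therefore expected to be weaker, with a 3.0-fold higher number from compound 1 to compound 4 (0.48 log units; beyond the scatter), and the estimate for compound 4 is 15000 nM, between 4000 nM and 50000 nM.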

Compound 4, half-maximal inhibitory concentration: 12400 nM
The estimate for compound 4 lay 1.2-fold (0.08 log units) above the measured number; the range from low to high includes it.
By their numbers in this assay, from the lowest: compounds 2 and 1 (each within the scatter of the next); then compound 4. At a limit, above all of these: compound 3.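

In this assay, among these compounds, this is the first direct reading at this position on the five-membered aromatic ring: a 2.5-fold higher number from compound 1 to compound 4 (0.40 log units; beyond the scatter). The loss is real but modest, and compound 4, with no ring on this carbon, still gives a measured number and not a limit, so among the compounds shown an aromatic ring here is not required for activity. Nothing given here explains why tert-butyl falls short of 4-chlorophenyl at this carbon.

The compounds shown leave open whether the difference follows from the aromatic ring itself, from its chlorine, or from the size of the group, which a cyclohexyl ring or an unsubstituted phenyl paired with the same sulfur side chain could help separate. On these data alone, it also remains open whether this step keeps its size when a different group sits on the sulfur chain.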